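The source may report more compounds than this note shows. Statements on the series, on what has been measured and on what is new or still open speak of the compounds shown alone.

Notes on the series. Compound 1 `Cc1ccc(-c2csc(NC(=O)COc3ccccc3C)n2)cc1` in a functional assay on MCF7 cells (Homo sapiens) for cytotoxicity, read by trypan blue exclusion, with a stated time of 48 h (on this read-out higher numbers stand for weaker inhibition and lower numbers for stronger inhibition), gives 53200 nM. Compound 2 `Cc1ccccc1OCC(=O)Nc1nc(-c2ccc(Cl)cc2)cs1` in this assay gives 62800 nM; its difference from compound 1 is chloro in place of methyl on an aromatic carbon, and the step is a 1.2-fold higher number from compound 1 to compound 2 (0.07 log units; within the scatter). Compound 3 `Cc1ccc(OCC(=O)Nc2nc(-c3ccc(C)cc3)cs2)cc1` in this assay gives 41400 nM. The core of compound 3 differs from the core of compound 1 by 4-methylphenyl in place of 2-methylphenyl on an oxygen on a saturated carbon, with a step of a 1.3-fold lower number from compound 1 to compound 3 (0.11 log units; within the scatter). All three numbers sit within the scatter of one another, so no order among them is claimed.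

Compound 4 `Cc1ccc(-c2csc(NC(=O)COc3ccc(Cl)cc3)n2)cc1` has not been measured in this assay. Its difference from compound 3 is chloro in place of methyl on an aromatic carbon. Read one bond further out, this is 4-methylphenoxy to 4-chlorophenoxy, whereas between compound 1 and compound 2 it read 4-methylphenyl to 4-chlorophenyl; the place itself is the same in both, so this is the same change made a second time. Within the data shown here, its only measured instance, a 1.2-fold higher number from compound 1 to compound 2 (0.07 log units; within the scatter), stayed within the scatter, and the two cores are within the scatter of each other. The expected step is therefore a 1.2-fold higher number from compound 3 to compound 4 (0.08 log units; within the scatter), resting on a 1.2-fold higher number from compound 1 to compound 2 (0.07 log units; within the scatter). Compound 4 is estimated at 50000 nM in this assay, with a range from 20000 nM to 120000 nM.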

Compound 4, half-maximal inhibitory concentration: 43700 nM
Beside the measured number, compound 4's estimate is 1.1-fold (0.06 log units) above it; low and high end bracket the measured number.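

Chloro in place of methyl on an aromatic carbon now stands on two cores in this assay, and the two readings do not differ: the same change on two cores in this assay, a 1.2-fold higher number (0.07 log units; within the scatter) from compound 1 to compound 2 and a 1.1-fold higher number (0.02 log units; within the scatter) from compound 3 to compound 4, 1.1-fold (0.05 log units) apart, within the scatter of two such steps. The new step is a 1.1-fold higher number from compound 3 to compound 4 (0.02 log units; within the scatter), and the swap of the whole aryl group on the oxygen gives a 1.2-fold lower number from compound 1 to compound 4 (0.09 log units; within the scatter), so neither step separates its two compounds. This shows that the exchange of methyl for chloro stayed within the scatter on both the core of compound 1 and the core of compound 3, but it does not show a real effect of any direction or size that carries over, since two small steps that agree could reflect scatter alone, and two cores say nothing about the rest of the series.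

Open, on these data alone, is whether any other group on that aromatic carbon, such as an amine, a carboxylic acid or a longer chain, would give a step beyond the scatter. Also open, as far as these compounds go, is whether such a step would then carry from one core to the other.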